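A few compounds are considered here, and "the series" means these few. Any claim that something is new, unique, unknown or untested is made for them only; others in the source may bear on it.

Compound 2 `CC(C)c1ccc(-c2sc(N)c(C(=O)c3ccc(Cl)cc3)c2CC(C)(C)C)cc1` gives 1% in an assay on CHO cells for displacement of a labelled ligand from adenosine receptor A1 (Homo sapiens), read by scintillation counting, tested at 10 uM; a lower number here means less inhibition, a higher number more inhibition at the concentration tested (going by the name of the read-out); compound 1 `CC(C)(C)Cc1c(-c2ccc(OC(F)(F)F)cc2)sc(N)c1C(=O)c1ccc(Cl)cc1` gives 1%, and the step of no change at the digits printed from compound 1 to compound 2 (within the scatter) shows that swapping the group on that ring left the read-out flat. Compound 3 `COc1ccc(-c2sc(N)c(C(=O)c3ccc(Cl)cc3)c2CC(C)(C)C)cc1` differs from compound 2 by methoxy in place of isopropyl on an aromatic carbon. Going by the values given here, only the step from compound 1 to compound 2 bears on this change, and it was flat, so no movement beyond the scatter is expected in this assay. Compound 3 is therefore estimated at 2%, range -8% to 12%, an expected step of a number 1 percentage points higher from compound 2 to compound 3 (within the scatter).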

Compound 3, a percentage reported as inhibition, at one concentration (the size of the read-out at that concentration, not a potency): 1%
Estimate against measurement, compound 3: 1 percentage points above, within the range that was stated.
By their numbers in this assay, from the lowest: compounds 1, 2 and 3 (each within the scatter of the next).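

In this assay the change from 4-isopropylphenyl to 4-methoxyphenyl gives no change at the digits printed from compound 2 to compound 3 (within the scatter) and replaces a group with no hydrogen-bond acceptor with one that has one. Methyl in place of trifluoromethyl on the oxygen gives no change at the digits printed from compound 1 to compound 3 (within the scatter), so all three groups at this place on the ring now read alike. No measurement here explains this flat read-out.

On these data alone, whether an amine or a carboxylic acid at this place would move the read-out remains open. All three compounds sit at the same low level, so these steps cannot show which changes to the shared core would raise it.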